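Amide variation on the shared piperidine carboxamide core

This account rests on a few compounds, and the source may have more. Where it says the series, first, only, none or still open, it means among the compounds named here.

Compound 2 `CC(C)N(C(=O)C1CCN(C(=O)c2ccc(S(C)(=O)=O)c([N+](=O)[O-])c2)CC1)C(C)C` carries a diisopropylamino group on the carbonyl carbon of the shared core. In an assay on isolated protein for inhibition of thyroid hormone receptor beta (Homo sapiens), read by fluorescence polarization (on this read-out higher numbers stand for weaker inhibition and lower numbers for stronger inhibition), compound 2 gives > 60000 nM, which is a limit of the assay and not a number. Compound 1 `CN1CCN(C(=O)C2CCN(C(=O)c3ccc(S(C)(=O)=O)c([N+](=O)[O-])c3)CC2)CC1`, with 4-methylpiperazin-1-yl on that carbonyl carbon, gives > 60000 nM in this assay, again a limit rather than a number. For the measured compounds named here, the step that the two limits leave unreadable from compound 1 to compound 2 stays unreadable from the two limits; the only evidence on the measured pair is the limit of > 60000 nM in this assay, at which 2 of the 2 values shown sit.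

Compound 3 `CS(=O)(=O)c1ccc(C(=O)N2CCC(C(=O)N3CCc4ccccc4C3)CC2)cc1[N+](=O)[O-]` is not yet measured. It differs from compound 2 by 1,2,3,4-tetrahydroisoquinolin-2-yl in place of diisopropylamino on a carbonyl carbon. Going by the values given here, no measured step bears on this change: the single measured step, a step that the two limits leave unreadable from compound 1 to compound 2, is itself unreadable, and both measured compounds sit at the limit, so no direction can be read from them. The estimate for compound 3 rests on that alone. The step that the limit leaves unreadable from compound 2 to compound 3 is expected to leave compound 3 near the limit rather than move it beyond the scatter. Compound 3 is estimated at 80000 nM, with a range from 15000 nM to 300000 nM, and will most likely be reported as a limit again.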

Compound 3, half-maximal inhibitory concentration: > 60000 nM
Compound 3: a limit, no number (the forecaster's own chance of this, stated with the estimate: 75%); the middle value is on the limit's open side.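

No new step can be read: compound 3, like compound 1 and compound 2, is reported only as a limit of the assay, so the steps among these three compounds cannot be read. The compounds shown leave open whether any group on this carbonyl carbon of the shared core gives a number in this assay rather than a limit.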